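Pyrrolidine hydroxamates: removing the lysyl amide

This account rests on a few compounds, and the source may have more. Where it says the series, first, only, none or still open, it means among the compounds named here.

Measured:
- compound 1, `CCCC[C@H](N)C(=O)N[C@@H]1C[C@H](C(=O)NO)N(S(=O)(=O)c2ccc(OC)cc2)C1`: 98 nM
- compound 2, `COc1ccc(S(=O)(=O)N2C[C@H](NC(=O)[C@@H](N)CCCCN)C[C@@H]2C(=O)NO)cc1`: 5.7 nM

In an assay on isolated protein for inhibition of matrix metalloproteinase-9 (Homo sapiens), read by fluorescence (on this read-out lower numbers stand for stronger inhibition and higher numbers for weaker inhibition), compound 2 gives the lowest of the two numbers, with compound 1 next at a 17-fold lower number from compound 1 to compound 2 (1.24 log units; beyond the scatter). Compound 3, `COc1ccc(S(=O)(=O)N2CCC[C@@H]2C(=O)NO)cc1`, carries hydrogen in place of ((1,5-diaminopentyl)carbonyl)amino on a saturated ring carbon. For the measured compounds named here, no measured step covers this change; the only step available, from compound 1 to compound 2, concerns the amino group within the leaving group and was large. Loss of the whole group is expected to raise the number, by an estimated 14-fold higher number from compound 2 to compound 3 (1.15 log units; beyond the scatter). For compound 3 the expected value in this assay is 80 nM, range 15 nM to 400 nM.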

Compound 3, half-maximal inhibitory concentration: 22 nM
The estimate for compound 3 lay 3.6-fold (0.56 log units) above the measured number; the measured number falls inside the stated range.
By their numbers in this assay, from the lowest: compound 2; then compound 3; then compound 1.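

In this assay, hydrogen on this saturated ring carbon gives a 3.9-fold higher number from compound 2 to compound 3 (0.59 log units; beyond the scatter), so the full ((1,5-diaminopentyl)carbonyl)amino group is not needed for inhibition, though it still adds to it. The group of 9 heavy atoms in compound 1 falls behind hydrogen, with a 4.5-fold lower number from compound 1 to compound 3 (0.65 log units; beyond the scatter), so among these compounds a side chain improves on hydrogen only when it carries the terminal amino group. Nothing at hand accounts for either step. Open, on these data alone, is how a shorter chain ending in an amine, or a carboxylic acid at the chain end, would compare with compound 2.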